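A few compounds are considered here, and "the series" means these few. Any claim that something is new, unique, unknown or untested is made for them only; others in the source may bear on it.

Measured so far:
compound 1 `C[C@H](Oc1ccc(S(C)(=O)=O)cc1C(=O)N1Cc2ccccc2C1)C(F)(F)F`, an assay on CHO cells for inhibition of sodium- and chloride-dependent glycine transporter 1 (Homo sapiens), read by scintillation counting (on this read-out lower numbers stand for an effect already at smaller amounts and higher numbers for an effect only at larger amounts of compound), 2540 nM
compound 2 `C[C@H](Oc1ccc(S(C)(=O)=O)cc1C(=O)N1Cc2ccc(C(F)(F)F)cc2C1)C(F)(F)F`, this assay 21 nM

Compound 1 stands highest of the two numbers; the step of a 120-fold lower number from compound 1 to compound 2 (2.08 log units; beyond the scatter) is large and beyond the scatter. Compound 3 `COc1ccc2c(c1)CN(C(=O)c1cc(S(C)(=O)=O)ccc1O[C@@H](C)C(F)(F)F)C2` differs from compound 1 by methoxy in place of hydrogen on an aromatic carbon, a substituent entering on the same fused aromatic system as in compound 2, though a different group. For the measured compounds named here, the only bearing step is from compound 1 to compound 2. For compound 3 a lower number with a smaller step is expected, estimated as a 6.4-fold lower number from compound 1 to compound 3 (0.80 log units; beyond the scatter). Compound 3 is estimated at 400 nM, range 100 nM to 1500 nM.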

Compound 3, half-maximal effective concentration: 180 nM
The estimate for compound 3 lay 2.2-fold (0.35 log units) above the measured number; low and high end bracket the measured number.
By their numbers in this assay, from the lowest: compound 2; then compound 3; then compound 1.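

In this assay, a second group on this aromatic carbon also lowers the number (a 14-fold lower number from compound 1 to compound 3 (1.15 log units; beyond the scatter)), so the drop from hydrogen is not confined to trifluoromethyl. The identity of the group still counts: methoxy in place of trifluoromethyl gives an 8.6-fold higher number from compound 2 to compound 3 (0.93 log units; beyond the scatter), and compound 2 keeps the lowest number of the three. No measured data on hand account for the gap between the two groups.

Still open, on these data alone, is whether chlorine, a nitrile or an amine on this carbon would give a number nearer that of compound 2 or of compound 3. A longer ether chain in place of methoxy is equally unresolved.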